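Solubility of a dimethylcarbamoyl analogue estimated from three acids and amides

The source may hold more compounds than are shown below. What is called first, only, known or untested is meant among the compounds shown, and "the series" means these compounds.

Compound 1 `COc1ccc(-c2cc(-c3ccc(S(=O)(=O)NC4CC4)cc3)cnc2N)cn1`: 6.3 ug/mL
Compound 2 `COc1ccc(-c2cc(-c3ccc(C(F)(F)F)cc3)cnc2N)cn1`: 1.6 ug/mL
Compound 3 `COc1ccc(-c2cc(-c3ccc(C(=O)O)cc3)cnc2N)cn1`: 6.3 ug/mL

In a physicochemical assay for solubility, read by nephelometry, in phosphate buffer, measured as kinetic solubility, at pH 6.5 (on this read-out lower numbers stand for lower solubility and higher numbers for higher solubility), compound 3 stands level with compound 1 at the digits shown, the two together forming the top of this small set, while a 3.9-fold higher number from compound 2 to compound 3 (0.60 log units; beyond the scatter). Compound 4 `COc1ccc(-c2cc(-c3ccc(C(=O)N(C)C)cc3)cnc2N)cn1` differs from compound 3 by dimethylamino in place of hydroxy on a carbonyl carbon. Going by the values given here, no measured step covers this change directly. Among the compounds with values here, the steps that bear on it are no change at the digits printed from compound 1 to compound 3 (within the scatter) and a 3.9-fold higher number from compound 2 to compound 3 (0.60 log units; beyond the scatter), which show that two distinct groups on the same aromatic carbon sit within the scatter of each other, while the trifluoromethyl of compound 2 sits apart. The step is therefore expected to be small, a 1.6-fold lower number from compound 3 to compound 4 (0.20 log units; within the scatter), with a slight lean downward. Compound 4 is estimated at 4 ug/mL, between 1.5 ug/mL and 10 ug/mL.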

Compound 4, solubility: > 100 ug/mL
Compound 4 was reported as a limit; the forecaster's own chance of this, stated with the estimate: 5%; middle value at least 25-fold (1.39 log units) from the limit.
By their numbers in this assay, from the lowest: compound 2; then compounds 1 and 3 (each within the scatter of the next). At a limit, above all of these: compound 4.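

In this assay compound 4 gives > 100 ug/mL as a limit of the assay, not a number. Dimethylamino in place of hydroxy on the carbonyl carbon proves a large step (an at least 15-fold higher number from compound 3 to compound 4 (1.20 log units; beyond the scatter)), so carboxy and dimethylcarbamoyl do not read alike here, although both hold a carbonyl. The steps from cyclopropylsulfamoyl (an at least 15-fold higher number from compound 1 to compound 4 (1.20 log units; beyond the scatter)) and trifluoromethyl (an at least 62-fold higher number from compound 2 to compound 4 (1.79 log units; beyond the scatter)) are also large, so this aromatic carbon carries a far wider range than the earlier groups showed.

From the compounds shown here alone, how far compound 4 lies past its limit stays open. So does whether a primary carboxamide or a pyrrolidine amide would read the same way.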